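This account rests on a few compounds, and the source may have more. Where it says the series, first, only, none or still open, it means among the compounds named here.

Measured compounds:
- compound 1, `[N-]=[N+]=NC[C@@H]1O[C@H](CO)[C@@H](O)[C@H](O)[C@H]1O`: 15800000 nM
- compound 2, `NC[C@H]1O[C@H](CO)[C@@H](O)[C@H](O)[C@H]1O`: 31600000 nM
- compound 3, `O=C(Nc1ccccc1)[C@H]1O[C@H](CO)[C@@H](O)[C@H](O)[C@H]1O`: 12600000 nM

All three were tested in an assay on isolated protein (Sus scrofa) for inhibition of glycogen phosphorylase, brain form (Homo sapiens); a higher number here means a weaker inhibitor, a lower number a stronger inhibitor. Compound 3 gives 12600000 nM, the lowest of the three numbers. Compound 1 gives 15800000 nM, which lies within the usual scatter of compound 3, so the two cannot be told apart on these numbers. Compound 2 gives 31600000 nM, a gap beyond the scatter, so compound 2 is the weaker of that pair. None of the three is a strong inhibitor; all numbers sit far up the scale.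

Compound 4, `O=C(Nc1ccccc1)[C@@H]1O[C@H](CO)[C@@H](O)[C@H](O)[C@H]1O`, has not yet been measured. Compared with compound 3, (the two compounds have the same atoms and bonds and differ only in configuration as drawn: 1 of 5 stereo elements differ; a stereocentre at a saturated ring carbon is drawn S in compound 3 and R in compound 4). For the measured compounds named here, no step between measured compounds speaks to such a change in configuration, so there is nothing to anchor a direction. A change at a ring stereocentre can shift a number either way, and a step beyond the scatter is plausible in either direction. As a central guess, compound 4 is expected to land somewhat above compound 3, with the step from compound 3 to compound 4 estimated at a 2.0-fold higher number from compound 3 to compound 4 (0.30 log units; within the scatter). Compound 4 is therefore estimated at 25000000 nM in this assay, within a range of 8000000 nM to 80000000 nM.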

Compound 4, inhibition constant: 5010000 nM
Beside the measured number, compound 4's estimate is 5.0-fold (0.70 log units) above it; measured number outside the range, below it.
By their numbers in this assay, from the lowest: compound 4; then compounds 3, 1 and 2 (each within the scatter of the next, the first and the last beyond it).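

In this assay, redrawing a single saturated ring carbon from S to R gives a 2.5-fold lower number from compound 3 to compound 4 (0.40 log units; beyond the scatter), a modest step but one that lies beyond the usual scatter. For the compounds shown here, this is the first direct sign that the arrangement at this ring carbon matters for inhibition, and here the R form gives the lower number, which means the stronger inhibitor of the pair. The step can be assigned to that one stereocentre and to nothing else, because no atom or bond changes between the two compounds, as shown by this: the fact that compounds 3 and 4 differ only in the configuration as drawn

This single pair cannot show whether the same change in configuration would move the number in the same direction with another group in place of the phenyl amide, such as a carboxylic acid or a naphthyl amide. Also open, as far as these compounds go, is what a substituent on the phenyl ring, such as a methoxy group or a chlorine atom, would do to the number of compound 4, which stands at 5010000 nM.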